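The compounds below may be only part of what the source reports. "The series", "measured", "known", "first", "only" and "open" are said of these compounds alone.

Measured compounds in the series:

compound 1, `O=C(CCCCCCc1ccccc1)N1CCCC1`, 12900 nM
compound 2, `O=C(CCCCCCc1ccc(Cl)cc1)N1CCCC1`, 34500 nM
compound 3, `O=C(CCCCCCc1ccccn1)N1CCCC1`, for which only a limit is reported

All values come from an assay on HEK293 cells for inhibition of N-acylethanolamine-hydrolyzing acid amidase (Rattus norvegicus), read by LC-MS, with a stated time of 30 min; a lower number here means a stronger inhibitor, a higher number a weaker inhibitor. Compound 1 carries a phenyl at the chain end and gives 12900 nM. Compound 2 gives 34500 nM, a step of a 2.7-fold higher number from compound 1 to compound 2 (0.43 log units; beyond the scatter). For compound 3 this assay reports only a limit, > 100000 nM. Compound 3 thus stands at the weak end of the series, at the limit of > 100000 nM in this assay, at which 1 of the 3 values shown sits, and the step to it is an at least 7.7-fold higher number from compound 1 to compound 3 (0.88 log units; beyond the scatter).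

Compound 4, `O=C(CCCCCCc1cccs1)N1CCCC1`, is not yet measured. It differs from compound 3 by thiophen-2-yl in place of pyridin-2-yl on a saturated chain carbon, six bonds along the chain from a carbonyl carbon. For the measured compounds named here, the one step that bears on the ring type is from compound 1 to compound 3, where the pyridin-2-yl pushed the value past the limit. Thiophen-2-yl replaces a six-membered ring with a five-membered one; no measured step tells how it compares with phenyl, so the expectation is that compound 4 lands between compound 1 and the limit. Compound 4 is expected to give 25000 nM (range 8000 nM to 100000 nM), an expected step of an at least 4.0-fold lower number from compound 3 to compound 4 (0.60 log units; beyond the scatter).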

Compound 4, half-maximal inhibitory concentration: 14100 nM
Estimate against measurement, compound 4: 1.8-fold (0.25 log units) above, within the range that was stated.
By their numbers in this assay, from the lowest: compounds 1 and 4 (each within the scatter of the next); then compound 2. At a limit, above all of these: compound 3.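

On a saturated chain carbon, six bonds along the chain from a carbonyl carbon, this assay does not separate thiophen-2-yl from phenyl, with a 1.1-fold higher number from compound 1 to compound 4 (0.04 log units; within the scatter), so among these compounds a five-membered aromatic ring serves as well as a six-membered one. The loss seen with pyridin-2-yl does not extend to every aromatic ring with one hetero atom, as the change to thiophen-2-yl gives an at least 7.0-fold lower number from compound 3 to compound 4 (0.85 log units; beyond the scatter). The value of compound 3 is a limit and not a number: the limit of > 100000 nM in this assay, at which 1 of the 4 values shown sits.

Still open, from the compounds shown here alone, is whether furan-2-yl or thiophen-3-yl at this place would read like compound 4, and whether pyridin-3-yl or pyridin-4-yl would read like compound 3. Also open, going by these compounds, is whether chloro on the thiophen-2-yl ring would move the number as it did in a 2.7-fold higher number from compound 1 to compound 2 (0.43 log units; beyond the scatter).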